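Replacing dimethylamino with ethoxycarbonyl on compound 3

The source may hold more compounds than are shown below. What is called first, only, known or untested is meant among the compounds shown, and "the series" means these compounds.

compound 1 `O=C(CSc1nc2c(c(=O)n1-c1ccccc1)SCC2)Nc1ccc(-c2ccccn2)cc1`: 4 nM
compound 2 `O=C(CSc1nc2c(c(=O)n1-c1ccccc1)SCC2)Nc1ccc(-c2ccncc2)cc1`: 3 nM
compound 3 `CN(C)c1ccc(NC(=O)CSc2nc3c(c(=O)n2-c2ccccc2)SCC3)cc1`: > 1000 nM

Of the compounds shown here, three with a shared core have been tested in an assay on L cells for inhibition of Protein-serine O-palmitoleoyltransferase porcupine (Mus musculus), read by reporter gene assay, with a stated time of 24 h; a lower number here means that less compound is needed, a higher number that more compound is needed for the effect. Compound 1 gives 4 nM and compound 2 gives 3 nM; the step of a 1.3-fold lower number from compound 1 to compound 2 (0.12 log units; within the scatter) lies within the scatter. For compound 3 the reading > 1000 nM is a limit of the assay, not a number (the limit of > 1000 nM in this assay, at which 1 of the 3 values shown sits). Compound 3 therefore stands at the weak end of what has been measured: an at least 250-fold higher number from compound 1 to compound 3 (2.39 log units; beyond the scatter) and an at least 330-fold higher number from compound 2 to compound 3 (2.52 log units; beyond the scatter).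

Compound 4 `CCOC(=O)c1ccc(NC(=O)CSc2nc3c(c(=O)n2-c2ccccc2)SCC3)cc1` is not yet measured. It differs from compound 3 in one place: ethoxycarbonyl in place of dimethylamino on an aromatic carbon. For the measured compounds named here, no measured step involves ethoxycarbonyl, so the two large steps above show only that the dimethylamino compound is weak, not where ethoxycarbonyl will land. The expected step is an at least 3.3-fold lower number from compound 3 to compound 4 (0.52 log units; beyond the scatter), with wide uncertainty. Compound 4 is estimated at 300 nM, between 30 nM and 3000 nM.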

Compound 4, half-maximal effective concentration: 300 nM
For compound 4 middle estimate and measured number coincide at the digits printed; measured number inside the range.
By their numbers in this assay, from the lowest: compounds 2 and 1 (each within the scatter of the next); then compound 4. At a limit, above all of these: compound 3.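

A group without a ring on this aromatic carbon can give a measurable number, and the change from dimethylamino to ethoxycarbonyl gives an at least 3.3-fold lower number from compound 3 to compound 4 (0.52 log units; beyond the scatter). The reading for compound 3 is a limit, so the true size of that step stays unknown: the limit of > 1000 nM in this assay, at which 1 of the 4 values shown sits.

Ethoxycarbonyl still falls well short of both pyridine groups, with a 100-fold higher number from compound 2 to compound 4 (2.00 log units; beyond the scatter) and a 75-fold higher number from compound 1 to compound 4 (1.88 log units; beyond the scatter). On these data alone, it remains open whether a carboxylic acid or a primary amide here would behave like the ester. A plain phenyl ring would show whether a ring alone is enough or whether the pyridine nitrogen is also needed.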